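From furan-2-yl to ethynyl on a shared core

The source may report more compounds than this note shows. Statements on the series, on what has been measured and on what is new or still open speak of the compounds shown alone.

Compound 1 `CSc1ncnc2c1c(-c1ccccc1)cn2[C@@H]1O[C@H](CO)[C@@H](O)[C@H]1O` gives > 20000 nM as a limit
Compound 2 `CNc1ncnc2c1c(-c1ccco1)cn2[C@@H]1O[C@H](CO)[C@@H](O)[C@H]1O` gives 620 nM as a number

In a functional assay on HL-60 cells (Homo sapiens) for antiproliferative activity, read by XTT assay, with a stated time of 72 h (a lower number here means a stronger inhibitor, a higher number a weaker inhibitor), compound 2 gives 620 nM as the only number shown so far. Compound 1 reads > 20000 nM and this is a limit of the assay.

Compound 3 `C#Cc1cn([C@@H]2O[C@H](CO)[C@@H](O)[C@H]2O)c2ncnc(NC)c12` carries ethynyl in place of furan-2-yl on an aromatic carbon of the shared core. Going by the values given here, no measured step covers this change. In this assay only a small shift toward stronger inhibition is expected, and none clearly beyond the scatter. The estimated change runs a 1.6-fold lower number from compound 2 to compound 3 (0.19 log units; within the scatter) and remains uncertain. Compound 3 is estimated at 400 nM with an expected range from 60 nM to 3000 nM once measured.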

Compound 3, half-maximal inhibitory concentration: 9060 nM
Estimate against measurement, compound 3: 23-fold (1.36 log units) below; measured number outside the range, above it.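

In this assay, this position proves sensitive to the group it carries: ethynyl in place of furan-2-yl on an aromatic carbon gives a 15-fold higher number from compound 2 to compound 3 (1.16 log units; beyond the scatter), a large step. The earlier compounds shown here differ in more than one place and could not show this effect of a single change at this position. Nothing shown here accounts for the step.

As far as these compounds go, it remains open whether the ring of furan-2-yl matters here or the particular group. A thiophen-2-yl group or a longer alkyne chain at this place would help separate the two.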